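A few compounds are considered here, and "the series" means these few. Any claim that something is new, unique, unknown or untested is made for them only; others in the source may bear on it.

Measured compounds in an assay on isolated protein for displacement of a labelled ligand from metabotropic glutamate receptor 5 (Homo sapiens), with a stated time of 60 min, tested at 1 uM; on this read-out lower numbers stand for less inhibition and higher numbers for more inhibition at the one concentration tested (going by the name of the read-out):
- compound 1 `Cc1ccc(S(=O)(=O)c2cnc3c(F)cccc3c2N2CCC(C)CC2)cc1F` gives 93%
- compound 2 `CCN(CC)c1c(S(=O)(=O)c2ccc(C)cc2)cnc2ccccc12` gives 78.3%

Compound 2 stands lowest of the two numbers; its nearest neighbour is compound 1, whose number in this assay is higher by a margin beyond the usual scatter. The two differ in more than one place, so the pair says only what the two values show, and no single step can be read from it.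

Compound 3 `Cc1ccc(S(=O)(=O)c2cnc3ccccc3c2NCc2ccccc2)cc1` is not yet measured. It differs from compound 2 in one place: benzylamino in place of diethylamino on an aromatic carbon. The group that leaves is an open chain; the group that enters carries a ring and adds a hydrogen-bond donor. Going by the values given here, nothing among the measured compounds isolates this change, so there is no measured step to lean on.

The expectation for compound 3 is a step of a number 8.3 percentage points lower from compound 2 to compound 3 (within the scatter), that is no change beyond the scatter or at most a modest decrease. Compound 3 is therefore expected to give about 70% in this assay, with a plausible range from 40% to 92%.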

Compound 3, a percentage reported as inhibition, at one concentration (the size of the read-out at that concentration, not a potency): 73.5%
For compound 3 the middle estimate is 3.5 percentage points below the measured one; the range from low to high includes it.
By their numbers in this assay, from the lowest: compounds 3 and 2 (each within the scatter of the next); then compound 1.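

In this assay, going by these compounds alone, benzylamino in place of diethylamino on the aromatic carbon opposite the ring nitrogen gives a number 4.8 percentage points lower from compound 2 to compound 3 (within the scatter), the first comparison that isolates this position. At this one test concentration, the read-out does not separate an open chain without a hydrogen-bond donor from a group that carries a six-membered aromatic ring and a hydrogen-bond donor, so this position accepts both groups without a change beyond the scatter. No measured property of either group bears on this result.

The compounds shown leave open whether the ring and the donor each matter when taken apart, which a benzyl(methyl)amino group, keeping the ring without the amine hydrogen, or a morpholine or a primary amine at the same carbon could test. Compound 1 differs from compound 2 and compound 3 in more than one place, so how much of its number belongs to the group at this position and how much to its other changes remains unresolved.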